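This account rests on a few compounds, and the source may have more. Where it says the series, first, only, none or still open, it means among the compounds named here.

Working notes on the series. In a functional assay on SW480 cells (Homo sapiens) for antiproliferative activity, read by MTT assay, with a stated time of 48 h (a lower number here means a stronger inhibitor, a higher number a weaker inhibitor), compound 1 (`CC(C)=CCC[C@]1(C)/C=C/[C@@H](OC(=O)C=C(C)C)[C@](C)(O)/C=C/C(=O)/C(CN(C(C)C)C(C)C)=C\C1`) gives 750 nM, and compound 2 (`CC(C)=CCC[C@]1(C)/C=C/[C@@H](OC(=O)C=C(C)C)[C@](C)(O)/C=C/C(=O)/C(C(=O)N(C)C)=C\C1`) gives 3300 nM, the higher of the two numbers. Compound 3 (`CC(C)=CCC[C@]1(C)/C=C/[C@@H](OC(=O)C=C(C)C)[C@](C)(O)/C=C/C(=O)/C(C(=O)N(C(C)C)C(C)C)=C\C1`) differs from compound 2 by diisopropylamino in place of dimethylamino on a carbonyl carbon. Among the measured compounds shown here, only one measured step bears on this, a 4.4-fold higher number from compound 1 to compound 2 (0.64 log units; beyond the scatter), and it swaps dimethylcarbamoyl for (diisopropylamino)methyl, so it is only partial guidance. Compound 3 keeps the carbonyl of compound 2 and gains the diisopropylamino of compound 1. A small drop in this assay is therefore expected, possibly none beyond the scatter, and the expected change is a 1.4-fold lower number from compound 2 to compound 3 (0.16 log units; within the scatter). The estimate for compound 3 is 2300 nM, within a range of 950 nM to 5500 nM.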

Compound 3, half-maximal inhibitory concentration: 16000 nM
The estimate for compound 3 lay 7.0-fold (0.84 log units) below the measured number; the measured number lies above the stated range.
By their numbers in this assay, from the lowest: compound 1; then compound 2; then compound 3.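

On the carbonyl carbon whose other neighbour is the double-bonded ring carbon, diisopropylamino is clearly worse than dimethylamino in this assay, with a 4.8-fold higher number from compound 2 to compound 3 (0.69 log units; beyond the scatter) on that change. The diisopropylamino group therefore does not bring the lower number of compound 1 to the amide, and the carbonyl-bearing diisopropylcarbamoyl in place of (diisopropylamino)methyl gives a 21-fold higher number from compound 1 to compound 3 (1.33 log units; beyond the scatter) as the largest step in the set. No measurement here accounts for this loss. Still open, going by these compounds, is how a dimethylaminomethyl group would compare with (diisopropylamino)methyl on the double-bonded ring carbon, and whether a pyrrolidine amide would fit the trend seen between the two amides.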